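The source may hold more compounds than are shown below. What is called first, only, known or untested is meant among the compounds shown, and "the series" means these compounds.

In a functional assay on MV4-11 cells (Homo sapiens) for inhibition, read by resazurin assay, with a stated time of 72 h (on this read-out higher numbers stand for weaker inhibition of growth and lower numbers for stronger inhibition of growth), compound 1 `O=C1NCCC12CCN(c1c(Cl)cncc1-c1ccco1)CC2` gives 940 nM, and compound 2 `O=Cc1ccc(-c2cncc(Cl)c2N2CCC3(CCNC3=O)CC2)o1` gives 5190 nM, the higher of the two numbers and so the weaker inhibition of growth. Compound 3 `CCOCOCc1ccc(-c2cncc(Cl)c2N2CCC3(CCNC3=O)CC2)o1` has not yet been measured. It departs from compound 2 by one change: (ethoxymethoxy)methyl in place of formyl on an aromatic carbon. In short, (ethoxymethoxy)methyl stands in place of formyl on an aromatic carbon of the five-membered aromatic ring with 1 oxygen, next to the ring oxygen.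

For the measured compounds named here, only one measured step touches this place: a 5.5-fold higher number from compound 1 to compound 2 (0.74 log units; beyond the scatter), a modest step beyond the scatter, with formyl in place of hydrogen. Going by the values given here, no measured compound carries the (ethoxymethoxy)methyl group, so this step gives only a rough guide to size and none to direction. Removing the formyl group gave the lower number in compound 1 at 940 nM, so a slight lean away from compound 2 is expected in this assay. The estimated step, a 1.7-fold lower number from compound 2 to compound 3 (0.24 log units; within the scatter), is expected to stay small and within the scatter. For compound 3 the expected value is 3000 nM, with an estimated range from 1000 nM to 9000 nM.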

Compound 3, concentration for 50% growth inhibition: 2970 nM
For compound 3 the middle estimate is 1.0-fold (0.00 log units) above the measured one, and the stated range covers the measured number.
By their numbers in this assay, from the lowest: compound 1; then compounds 3 and 2 (each within the scatter of the next).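

In this assay, putting (ethoxymethoxy)methyl in place of formyl on the five-membered aromatic ring with 1 oxygen leaves the reading within the scatter (a 1.7-fold lower number from compound 2 to compound 3 (0.24 log units; within the scatter)), so this larger open chain, which has no double bond outside aromatic rings, and the smaller formyl group cannot be told apart here. Measured against hydrogen at the same carbon, the chain gives a modest step beyond the scatter (a 3.2-fold higher number from compound 1 to compound 3 (0.50 log units; beyond the scatter)), and formyl does the same (a 5.5-fold higher number from compound 1 to compound 2 (0.74 log units; beyond the scatter)), so both substituents shown at this position stand on the weaker side of compound 1, with neither compound going against this. No supporting evidence bears on why two such different groups read alike, and the result itself gives no reason.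

The compounds shown leave open whether a shorter group such as hydroxymethyl or methoxymethyl, an amine such as aminomethyl, or a carboxylic acid at this carbon would match or pass compound 1 at 940 nM. They also leave open whether a longer chain would keep the reading of compound 3 or shift it beyond the scatter.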